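Bromo in place of methoxy on the aryl ring

The source may hold more compounds than are shown below. What is called first, only, known or untested is meant among the compounds shown, and "the series" means these compounds.

Compound 1 `C=C1C(=O)ON(C)C1c1ccc(C)cc1`: 5800 nM
Compound 2 `C=C1C(=O)ON(C)C1c1ccc(OC)cc1`: 5500 nM

In a functional assay on NALM-6 cells (Homo sapiens) for antiproliferative activity (on this read-out higher numbers stand for weaker inhibition and lower numbers for stronger inhibition), compound 1 gives 5800 nM and compound 2 gives 5500 nM. Within the data shown here, the only step measured so far, a 1.1-fold lower number from compound 1 to compound 2 (0.02 log units; within the scatter), is too small to count as a change. Compound 2 therefore stands lowest of the two numbers, but its gap to compound 1 lies within the scatter, so neither can be called stronger. Compound 3 `C=C1C(=O)ON(C)C1c1ccc(Br)cc1` differs from compound 2 by bromo in place of methoxy on an aromatic carbon. Among the measured compounds shown here, no measured step carries a bromo group, so the one step known offers only an indirect hint. Compound 3 is expected to show a 1.2-fold lower number from compound 2 to compound 3 (0.09 log units; within the scatter), no step beyond the scatter. Compound 3 is estimated at 4500 nM, ranging from 1500 nM to 13000 nM.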

Compound 3, half-maximal inhibitory concentration: 4600 nM
Compound 3: the middle estimate sits 1.0-fold (0.01 log units) below what was measured; the range from low to high includes it.
By their numbers in this assay, from the lowest: compounds 3, 2 and 1 (each within the scatter of the next).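

In this assay there is a 1.2-fold lower number from compound 2 to compound 3 (0.08 log units; within the scatter) and a 1.3-fold lower number from compound 1 to compound 3 (0.10 log units; within the scatter), and both steps lie within the scatter. Bromo, which has no hydrogen-bond acceptor, therefore joins methoxy, which has one, and methyl at this position without a readable difference among compound 1, compound 2 and compound 3. No measured evidence is available to explain this result. From the compounds shown here alone, whether an amine, a carboxylic acid or a longer chain here would shift the number beyond the scatter remains open.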